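A few compounds are considered here, and "the series" means these few. Any claim that something is new, unique, unknown or untested is made for them only; others in the source may bear on it.

Of the compounds shown here, three sharing one core have been measured in an assay on MDA-MB-231 cells for displacement of a labelled ligand from C-X-C chemokine receptor type 4 (Homo sapiens), read by fluorescence and microscopy, with stated times of 10 min and 30 min (a lower number here means that less compound is needed, a higher number that more compound is needed for the effect), and they spread over a wide range. Compound 2 `Cc1ccccc1C(=O)NCc1ccc(CNS(=O)(=O)c2ccc(Cl)cc2)cc1` gives 1 nM, the lowest of the three numbers. Compound 1 `O=C(NCc1ccc(CNS(=O)(=O)c2ccccc2Cl)cc1)c1cccnc1` gives 100 nM, and compound 3 `O=C(NCc1ccc(CNS(=O)(=O)c2ccc(Cl)cc2)cc1)c1cccnc1` gives 1000 nM. Compound 4 `Cc1ccccc1C(=O)NCc1ccc(CNS(=O)(=O)c2cccc(Cl)c2)cc1` has not yet been measured; it differs from compound 2 in one place: 3-chlorophenyl in place of 4-chlorophenyl on a sulfonyl sulfur.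

For the measured compounds named here, two measured steps bear on this. The step of a 1000-fold higher number from compound 2 to compound 3 (3.00 log units; beyond the scatter) changes the amide side, which is left untouched here. The step of a 10-fold higher number from compound 1 to compound 3 (1.00 log units; beyond the scatter) moves only the chlorine on the sulfonyl phenyl, showing that the chlorine position counts, though that step was made with a different amide partner and did not involve 3-chlorophenyl. A change of modest size is therefore expected, more likely towards a higher number than a lower one, with real uncertainty in direction.

For compound 4 the expected step is a 3.0-fold higher number from compound 2 to compound 4 (0.48 log units; beyond the scatter). Compound 4 is thus estimated at 3 nM, with a likely range from 0.5 nM to 30 nM.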

Compound 4, effective concentration (reported as EC, without a stated level of effect): 100 nM
The estimate for compound 4 lay 33-fold (1.52 log units) below the measured number, outside the stated range (above it).
By their numbers in this assay, from the lowest: compound 2; then compounds 1 and 4 (each within the scatter of the next); then compound 3.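

Placing 3-chlorophenyl instead of 4-chlorophenyl on the sulfonyl sulfur gives a 100-fold higher number from compound 2 to compound 4 (2.00 log units; beyond the scatter) in this assay, even though the group that leaves and the group that enters contain the same atoms. The earlier chlorine move, a 10-fold higher number from compound 1 to compound 3 (1.00 log units; beyond the scatter), involved 2-chlorophenyl and had pyridin-3-yl on the carbonyl carbon, so it could not show how much the chlorine's position counts when 2-methylphenyl is there. Nothing available here explains why moving the chlorine has this effect.

The compounds shown leave open how 3-chlorophenyl behaves with pyridin-3-yl on the carbonyl carbon, and how 2-chlorophenyl behaves with 2-methylphenyl there. They also leave open whether a methoxy group or a fluorine atom could replace the chlorine on this ring and still give a number as low as that of compound 2, 1 nM.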